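A second methyl on the core of compound 1

A few compounds are considered here, and "the series" means these few. Any claim that something is new, unique, unknown or untested is made for them only; others in the source may bear on it.

In a functional assay on PC-3 cells (Homo sapiens) for cytotoxicity, read by WST assay, with a stated time of 72 h (a higher number here means a weaker inhibitor, a lower number a stronger inhibitor), compound 1 (`Cc1cccc2c1NC(=O)C2(c1ccc(O)cc1)C1CCCCCC1`) gives > 1000 nM as its result, which is a limit and not a number. Compound 4 (`Cc1ccc2c(c1C)NC(=O)C2(c1ccc(O)cc1)C1CCCCCC1`) differs from compound 1 by methyl in place of hydrogen on an aromatic carbon on the shared core, with methyl in place of hydrogen on an aromatic carbon, ortho to a methyl group. Compound 3 (`Cc1cc(C)c2c(c1)C(c1ccc(O)cc1)(C1CCCCCC1)C(=O)N2`) carries the same kind of exchange. Compound 3 gives > 1000 nM as its result, again a limit. Among the compounds with values here, that leaves a step that the two limits leave unreadable from compound 1 to compound 3 as the closest precedent. In this assay compound 2 (`O=C1Nc2c(C(F)(F)F)cccc2C1(c1ccc(O)cc1)C1CCCCCC1`) reaches 91 nM through a different exchange, trifluoromethyl in place of methyl, and the size of that change is an at least 10-fold lower number from compound 1 to compound 2 (1.04 log units; beyond the scatter) in this series. The three compounds together show the limit of > 1000 nM in this assay, at which 2 of the 3 values shown sit, and no more. Since compound 3 gives > 1000 nM as a limit with a methyl added, no gain beyond the scatter is expected from adding a methyl here. The estimated outcome is a step that the limit leaves unreadable from compound 1 to compound 4 and so no clear shift in either direction. For compound 4 the estimated value is 1500 nM within an expected range of 400 nM to 5000 nM and quite possibly only a limit again.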

Compound 4, half-maximal inhibitory concentration: > 1000 nM
Compound 4 was reported as a limit; the forecaster's own chance of this, stated with the estimate: 65%; the middle value does not contradict the limit.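

In this assay compound 4 gives > 1000 nM, which is a limit and not a number. Within the data shown here, compound 1 is also reported only as a limit, so no step between the two can be read. The compounds shown leave open whether this added methyl changes the result in either direction.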